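This account rests on a few compounds, and the source may have more. Where it says the series, first, only, none or still open, it means among the compounds named here.

Measured compounds:
compound 1 `O=c1[nH]c(=O)n([C@@H]2O[C@H](COP(=O)(O)O)[C@@H](O)[C@H]2O)cc1Br` — 48 ug/mL
compound 2 `O=c1[nH]c(=O)n([C@@H]2O[C@@H]3COP(=O)(O)O[C@H]3[C@H]2O)cc1I` — 359 ug/mL
compound 3 `O=c1[nH]c(=O)n([C@@H]2O[C@@H]3COP(=O)(O)O[C@H]3[C@H]2O)cc1Cl` — 278 ug/mL

Three compounds have been run in a functional assay on Raji cells (Homo sapiens); a higher number here means a weaker inhibitor, a lower number a stronger inhibitor. Compound 1 gives 48 ug/mL, the lowest of the three numbers; compound 3 stands nearest to it with 278 ug/mL, compound 2 furthest with 359 ug/mL. Going by the values given here, compounds 2 and 3 share a core that differs from that of compound 1 in how the phosphate is attached, so no single-change step connects compound 1 to either of them. Among the compounds with values here, the one measured step, a 1.3-fold lower number from compound 2 to compound 3 (0.11 log units; within the scatter), is the only halogen exchange in the set and it stays within the scatter.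

Compound 4 `O=c1[nH]c(=O)n([C@@H]2O[C@H](COP(=O)(O)O)[C@@H](O)[C@H]2O)cc1I` is not yet measured in this assay. It differs from compound 1 by iodo in place of bromo on an aromatic carbon. The step from compound 2 to compound 3 bears on this change, since it too swaps one halogen for another at the same site of the shared core, and it produced no shift beyond the scatter. On that basis no step beyond the scatter is expected in this assay from compound 1 to compound 4, in either direction; the expected step is a 1.1-fold higher number from compound 1 to compound 4 (0.06 log units; within the scatter). Within the data shown here, compound 4 is therefore estimated at 55 ug/mL, with a range from 20 ug/mL to 150 ug/mL, the width reflecting that only one halogen step, on a different core, supports this expectation.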

Compound 4, concentration for 50% inhibition: > 1000 ug/mL
Compound 4 ended at the assay's limit (the forecaster's own chance of this, stated with the estimate: 5%); middle value at least 18-fold (1.25 log units) away from the limit.
By their numbers in this assay, from the lowest: compound 1; then compounds 3 and 2 (each within the scatter of the next). At a limit, above all of these: compound 4.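

In this assay, the halogen on this aromatic carbon of the core of compound 1, two atoms from the ring nitrogen, turns out to matter: iodo in place of bromo gives an at least 20-fold higher number from compound 1 to compound 4 (1.31 log units; beyond the scatter). Going by these compounds alone, the only earlier halogen exchange, on the other core, was a 1.3-fold lower number from compound 2 to compound 3 (0.11 log units; within the scatter), so a halogen exchange at this site does not read the same in the two cases, although those two exchanges also involve different pairs of halogens. The value of compound 4 is a limit of the assay and not a number, so the new step marks only a minimum size: the limit of > 1000 ug/mL in this assay, at which 1 of the 4 values shown sits.

Open, from the compounds shown here alone, is what chloro, a methyl group or an amine on this carbon would give on the core of compound 1, and what bromo would give on the core of compound 2, which would help separate the part played by the core from that played by the halogen. The compounds shown also give no reason for the loss from bromo to iodo, and a single pair on one core cannot establish a trend across the halogens.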